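A few compounds are considered here, and "the series" means these few. Any claim that something is new, unique, unknown or untested is made for them only; others in the source may bear on it.

Measured compounds:
compound 1 `N#Cc1ccccc1CSc1ncnc2c1ncn2[C@@H]1O[C@H](CO)[C@@H](O)[C@H]1O` gives 38.9 nM in an assay on isolated protein for inhibition of Equilibrative nucleoside transporter 1 (Homo sapiens); on this read-out higher numbers stand for weaker inhibition and lower numbers for stronger inhibition
compound 2 `N#Cc1cccc(CSc2ncnc3c2ncn3[C@@H]2O[C@H](CO)[C@@H](O)[C@H]2O)c1` gives 36.3 nM
compound 3 `Cc1ccc(CSc2ncnc3c2ncn3[C@@H]2O[C@H](CO)[C@@H](O)[C@H]2O)cc1` gives 15.1 nM

Compound 3 has the lowest number of the three in this assay; its steps from the others, a 2.6-fold lower number from compound 1 to compound 3 (0.41 log units; beyond the scatter) and a 2.4-fold lower number from compound 2 to compound 3 (0.38 log units; beyond the scatter), are both beyond the scatter, while a 1.1-fold lower number from compound 1 to compound 2 (0.03 log units; within the scatter) is within it. Compound 4 `OC[C@H]1O[C@@H](n2cnc3c(SCc4ccc(Cl)c(Cl)c4)ncnc32)[C@H](O)[C@@H]1O` differs from compound 3 in one place: 3,4-dichlorophenyl in place of 4-methylphenyl on a saturated chain carbon bound to a sulfur. Going by the values given here, no measured step puts a 3,4-dichlorophenyl in place of a 4-methylphenyl, so the two steps into compound 3 bear on it only indirectly, showing that changes at the saturated chain carbon bound to a sulfur have so far moved the number modestly. The step into compound 4 is therefore expected to be small with no clear direction, estimated as a 1.2-fold higher number from compound 3 to compound 4 (0.08 log units; within the scatter). Compound 4 is expected at 18 nM, with a range from 6 nM to 55 nM.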

Compound 4, inhibition constant: 12.6 nM
Compound 4: middle estimate off by 1.4-fold (0.15 log units), on the high side, within the range that was stated.
By their numbers in this assay, from the lowest: compounds 4 and 3 (each within the scatter of the next); then compounds 2 and 1 (each within the scatter of the next).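

In this assay, 3,4-dichlorophenyl brings chlorine onto a saturated chain carbon bound to a sulfur, and the position accepts it: a 1.2-fold lower number from compound 3 to compound 4 (0.08 log units; within the scatter) is within the scatter. The cyanophenyl compounds stand apart from this new group, with a 2.9-fold lower number from compound 2 to compound 4 (0.46 log units; beyond the scatter) and a 3.1-fold lower number from compound 1 to compound 4 (0.49 log units; beyond the scatter) both beyond the scatter, so compound 3 and compound 4 now form a pair separate from compound 1 and compound 2. Nothing available explains that separation. As far as these compounds go, whether a carboxylic acid or an amine on the phenyl ring, or a longer chain in place of the benzyl group, would keep the number in this range remains open.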